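A few compounds are considered here, and "the series" means these few. Any claim that something is new, unique, unknown or untested is made for them only; others in the source may bear on it.

Working notes on the benzyl ester series sharing the purine-derived core of compound 1 `O=C(CN(c1ncnc2c1ncn2C1CCCCO1)C1CC1)N[C@@H](CO)C(=O)OCc1ccccc1`. In a functional assay on the whole organism (Tail, strain ICR) with Mus musculus as the target, in the tail flick test, with a stated time of 60 min, at a dose of 25 umol/kg by the oral route (a lower number here means a weaker effect, a higher number a stronger effect of the compound at the dose given), compound 1 gives 46.7%. Compound 2 `CC(C)[C@H](NC(=O)CN(c1ncnc2c1ncn2C1CCCCO1)C1CC1)C(=O)OCc1ccccc1` gives 34.9%, and compound 3 `CC[C@H](C)[C@H](NC(=O)CN(c1ncnc2c1ncn2C1CCCCO1)C1CC1)C(=O)OCc1ccccc1` gives 27.4%. Compound 3 stands lowest of the three numbers: the nearer step is a number 7.5 percentage points lower from compound 2 to compound 3 (within the scatter), so no order between these two can be claimed, while the further step is a number 19.3 percentage points lower from compound 1 to compound 3 (beyond the scatter), which is beyond the scatter. Compound 1 also sits above compound 2 by a number 11.8 percentage points lower from compound 1 to compound 2 (beyond the scatter).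

Compound 4 `O=C(CN(c1ncnc2c1ncn2C1CCCCO1)C1CC1)NCC(=O)OCc1ccccc1` has not yet been measured. It differs from compound 3 by hydrogen in place of sec-butyl on a saturated chain carbon bound to an amide-type nitrogen and a carbonyl carbon. Among the measured compounds shown here, the steps that bear on this are the sec-butyl introductions and extensions, a number 19.3 percentage points lower from compound 1 to compound 3 (beyond the scatter) and a number 7.5 percentage points lower from compound 2 to compound 3 (within the scatter), both of which lowered the read-out as the side chain grew. Removing the side chain entirely is therefore expected to give a modest rise in this assay, of roughly a number 9.6 percentage points higher from compound 3 to compound 4 (within the scatter), though the hydroxymethyl case gives no direct guide for a bare hydrogen. Compound 4 is estimated at 37%, with a range from 22% to 54%.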

Compound 4, a percentage reported as activity, at one dose (the size of the read-out at that dose, not a potency): 40.4%
The estimate for compound 4 lay 3.4 percentage points below the measured number, within the range that was stated.
By their numbers in this assay, from the lowest: compounds 3, 2, 4 and 1 (each within the scatter of the next, the first and the last beyond it).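

Among the compounds shown here, with hydrogen in place of sec-butyl on a saturated chain carbon bound to an amide-type nitrogen and a carbonyl carbon, this assay shows a number 13 percentage points higher from compound 3 to compound 4 (beyond the scatter) as the one step from the bare carbon that clears the scatter. Hydrogen in place of isopropyl gives a number 5.5 percentage points higher from compound 2 to compound 4 (within the scatter) and hydrogen in place of hydroxymethyl gives a number 6.3 percentage points lower from compound 1 to compound 4 (within the scatter) and so neither group can be separated from hydrogen here, which leaves sec-butyl as the only side chain of the three that stands apart from it. Nothing measured on these compounds accounts for these differences.

Still open, as far as these compounds go, is how a carboxylic acid, an amine or a longer chain on this carbon would compare with hydrogen. A phenyl ring at the same place is equally undecided, and all these readings rest on a single dose and time.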